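Methyl in place of chloro on the arylpiperazine end

A few compounds are considered here, and "the series" means these few. Any claim that something is new, unique, unknown or untested is made for them only; others in the source may bear on it.

Two members of this series have been measured in an assay on HEK293 cells for inhibition of Voltage-dependent T-type calcium channel subunit alpha-1G (Homo sapiens), read by fluorescence, tested at 10 uM; a higher number here means more inhibition at the concentration tested (going by the name of the read-out), a lower number less inhibition. Compound 1, `CCCc1nc(-c2ccccc2)c(CNCCN2CCN(c3ccc(F)cc3)CC2)o1`, gives 54.1% in this assay. Compound 2, `CCCc1nc(-c2ccccc2)c(CNCCCN2CCN(c3ccccc3Cl)CC2)o1`, gives 64.7% in this assay. For the measured compounds named here, of the two numbers known, that of compound 2 is the higher, and the gap to compound 1 lies beyond the scatter of repeated measurements. The two compounds differ in more than one place, so no single step can be read from that pair; only the two values themselves are shown.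

Compound 3, `CCCc1nc(-c2ccccc2)c(CNCCCN2CCN(c3ccccc3C)CC2)o1`, has not yet been measured. It differs from compound 2 by methyl in place of chloro on an aromatic carbon, a swap of one heavy atom for one heavy atom, with no change in ring count, donors, acceptors or charge. Nothing measured here speaks to that swap directly. He therefore expects a step of a number 4.7 percentage points lower from compound 2 to compound 3 (within the scatter), that is, no change beyond the scatter. For compound 3 the estimate in this assay is 60%, with a range from 42% to 78%.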

Compound 3, a percentage reported as inhibition, at one concentration (the size of the read-out at that concentration, not a potency): 54.5%
Beside the measured number, compound 3's estimate is 5.5 percentage points above it; the range from low to high includes it.
By their numbers in this assay, from the lowest: compounds 1 and 3 (each within the scatter of the next); then compound 2.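

With compound 3 the series gains its first step that can be read at a single place: methyl in place of chloro on an aromatic carbon, ortho to a large group, gives a number 10.2 percentage points lower from compound 2 to compound 3 (beyond the scatter) in this assay at this position. The read-out therefore responds to this swap even though one heavy atom replaces one heavy atom, with no change in ring count, hydrogen-bond donors, hydrogen-bond acceptors or net charge, and of this pair the 2-chlorophenyl compound holds the higher value. The step is modest and rests on this single pair, and no measurement on hand explains it.

From the compounds shown here alone, whether other groups at this same place, such as fluoro, methoxy or trifluoromethyl, would give a value nearer that of chloro or of methyl remains open. Going by these compounds, it is also open whether the same swap would give a step of similar size on a longer chain or on the chain of compound 1, since a single pair cannot show how far this result carries across the series.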